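Methyl on the five-membered ring: outlook for compound 4

The compounds below may be only part of what the source reports. "The series", "measured", "known", "first", "only" and "open" are said of these compounds alone.

Measured in a functional assay for inhibition, with Homo sapiens as the target; a higher number here means a weaker inhibitor, a lower number a stronger inhibitor:
compound 1 `CCOC(=O)Cn1ncc2cncn2c1=O`: > 48000 nM, a limit of the assay
compound 2 `CCCc1nc(C)c2cnnc(SC)n12`: > 48000 nM, a limit of the assay
compound 3 `CCCc1nc(C)c2c(C)nnc(SC)n12`: > 48000 nM, a limit of the assay

The difference between the cores of compound 1 and compound 2 is not broken down here. The change methyl in place of hydrogen on an aromatic carbon gives a step that the two limits leave unreadable from compound 2 to compound 3, unreadable because of the limit of > 48000 nM in this assay, at which 3 of the 3 values shown sit.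

Compound 4 `CCOC(=O)Cn1ncc2c(C)ncn2c1=O` carries the same kind of change, (methyl in place of hydrogen on an aromatic carbon); the place differs, a five-membered aromatic ring with 2 nitrogen instead of a six-membered aromatic ring with 3 nitrogen ortho to a fused ring and para to a methylsulfanyl group. The step from the measured pair gives no usable size, so the expected step that the limit leaves unreadable from compound 1 to compound 4 rests on compound 1 alone and its value > 48000 nM. For compound 4 the estimate in this assay is 100000 nM, likely again only a limit.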

Compound 4, half-maximal inhibitory concentration: > 48000 nM
Compound 4: no number, only a limit (the forecaster's own chance of this, stated with the estimate: 85%); the middle value lies beyond the limit too.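

No step can be read from compound 1 to compound 4, because both values are limits: the limit of > 48000 nM in this assay, at which 4 of the 4 values shown sit. The compounds shown leave open whether methyl in place of hydrogen on an aromatic carbon changes the read-out in this assay at all.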